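The source may report more compounds than this note shows. Statements on the series, on what has been measured and on what is new or still open speak of the compounds shown alone.

Measured in a physicochemical assay for solubility, read by HPLC, with a stated time of 24 h; on this read-out lower numbers stand for lower solubility and higher numbers for higher solubility:
Compound 1 `COC(=O)CC1CCN(C[C@H]2CN(c3ccc(-n4cc(-c5ccccn5)cn4)c(F)c3)C(=O)O2)CC1` gives 92100 nM.
Compound 2 `O=C1O[C@@H](Cn2ccnc2)CN1c1ccc(-n2cc(-c3ccccn3)cn2)c(F)c1` gives 12300 nM.

Compound 1 stands highest of the two numbers; its nearest neighbour is compound 2, and the step of a 7.5-fold lower number from compound 1 to compound 2 (0.87 log units; beyond the scatter) lies beyond the scatter. Compound 3 `O=C1O[C@@H](Cn2ccnn2)CN1c1ccc(-n2cc(-c3ccccn3)cn2)c(F)c1` is not yet measured. It differs from compound 1 as follows: 1H-1,2,3-triazol-1-yl in place of 4-((methoxycarbonyl)methyl)piperidin-1-yl on a saturated chain carbon bound to a saturated ring carbon. Among the compounds with values here, the one measured step that bears on this change is a 7.5-fold lower number from compound 1 to compound 2 (0.87 log units; beyond the scatter), where a 1H-imidazol-1-yl replaced the same 4-((methoxycarbonyl)methyl)piperidin-1-yl at the same place. A 1H-1,2,3-triazol-1-yl is a closely related five-membered aromatic ring, so a step of similar size and direction is expected in this assay, namely a 7.7-fold lower number from compound 1 to compound 3 (0.89 log units; beyond the scatter). On that basis compound 3 is estimated to give 12000 nM, with a range from 4000 nM to 35000 nM.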

Compound 3, solubility: 247000 nM
Estimate against measurement, compound 3: 21-fold (1.31 log units) below; the measured number lies above the stated range.
By their numbers in this assay, from the lowest: compound 2; then compound 1; then compound 3.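

In this assay, the place on a saturated chain carbon bound to a saturated ring carbon does not treat these two five-membered aromatic rings alike: 1H-1,2,3-triazol-1-yl in place of 1H-imidazol-1-yl gives a 20-fold higher number from compound 2 to compound 3 (1.30 log units; beyond the scatter) and is a large step. The replacement of 4-((methoxycarbonyl)methyl)piperidin-1-yl can therefore go either way, as the triazole gives a 2.7-fold higher number from compound 1 to compound 3 (0.43 log units; beyond the scatter) while the imidazole gave a 7.5-fold lower number from compound 1 to compound 2 (0.87 log units; beyond the scatter) in the opposite direction. No measurement shown accounts for the gap between the two rings.

Going by these compounds, it remains open where other five-membered rings, such as 1H-pyrazol-1-yl or 1H-1,2,4-triazol-1-yl, would fall at this place. On these data alone, it is also open whether a simple amine such as dimethylamino would stay closer to compound 2 or to compound 3.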